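This account rests on a few compounds, and the source may have more. Where it says the series, first, only, none or still open, it means among the compounds named here.

Values so far in a functional assay on KB cells (Homo sapiens) for inhibition, with a stated time of 72 h; on this read-out lower numbers stand for stronger inhibition and higher numbers for weaker inhibition
compound 1 `COc1ccc(S(=O)(=O)N2CCc3cccc(-c4ccc(F)nc4)c32)cc1` gives 143 nM
compound 2 `COc1ccc(S(=O)(=O)N2CCc3cccc(-c4ccc(F)c(F)c4)c32)cc1` gives 45 nM
compound 3 `COc1ccc(-c2cccc3c2N(S(=O)(=O)c2ccc(OC)cc2)CC3)cc1` gives 337 nM

Compound 3 has the highest number of the three, which makes it the weakest inhibitor here. Compound 1 lies nearest to it and compound 2 furthest from it. All three share one core and differ only in the aromatic group attached to it.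

Compound 4 `COc1ccc(S(=O)(=O)N2CCc3cccc(-c4ccc(C#N)cc4)c32)cc1` keeps compound 3 unchanged apart from one group (cyano in place of methoxy on an aromatic carbon). In words, this is cyano in place of methoxy on an aromatic carbon, para to a large group, or 4-methoxyphenyl to 4-cyanophenyl.

Within the data shown here, two measured steps bear most directly on this change, as each involves the 4-methoxyphenyl group of compound 3 (a 2.4-fold higher number from compound 1 to compound 3 (0.37 log units; beyond the scatter); a 7.5-fold higher number from compound 2 to compound 3 (0.87 log units; beyond the scatter)). Both are modest, and in both the compound with the 4-methoxyphenyl group has the higher number. The third step (a 3.2-fold lower number from compound 1 to compound 2 (0.50 log units; beyond the scatter)) shows that the two groups without methoxy also differ from each other. Among the measured compounds shown here, no compound with a cyano group has been measured yet, and three compounds make a thin basis. A modest move toward a lower number is nevertheless expected in this assay (a 2.2-fold lower number from compound 3 to compound 4 (0.35 log units; beyond the scatter)). Compound 4 is estimated at 150 nM (expected range 50 nM to 450 nM).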

Compound 4, half-maximal inhibitory concentration: 31.1 nM
The estimate for compound 4 lay 4.8-fold (0.68 log units) above the measured number; measured number below the stated range.
By their numbers in this assay, from the lowest: compounds 4 and 2 (each within the scatter of the next); then compound 1; then compound 3.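

In this assay, among these compounds, putting cyano in place of methoxy on this aromatic carbon, para to a large group, gives the only step so far rated large (an 11-fold lower number from compound 3 to compound 4 (1.03 log units; beyond the scatter)), so a small change at this one spot on the ring can shift the number considerably. The 4-cyanophenyl group also stands clearly apart from 6-fluoropyridin-3-yl (a 4.6-fold lower number from compound 1 to compound 4 (0.66 log units; beyond the scatter)), but it cannot be separated from 3,4-difluorophenyl (a 1.4-fold lower number from compound 2 to compound 4 (0.16 log units; within the scatter)), a difference within the usual scatter, so two different groups at this position give numbers that cannot be told apart. No measurement shown here explains why the numbers move in this way.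

The compounds shown leave open whether trifluoromethyl, an amine or a carboxylic acid in the same place would give a number closer to that of the cyano compound or the methoxy compound, and whether cyano on another carbon of that ring would give a similar number. As far as these compounds go, all four compounds share one core, and all are read in this assay, so it also remains open whether this step holds with a different core or in other cells.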